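A few compounds are considered here, and "the series" means these few. Any claim that something is new, unique, unknown or untested is made for them only; others in the source may bear on it.

Among the measured compounds shown here, only two compounds built on the same shared core have been tested so far in a functional assay on A549 cells (Homo sapiens) for antiproliferative activity, read by MTT assay; on this read-out lower numbers stand for stronger inhibition and higher numbers for weaker inhibition. In that test, compound 1 `CC1(C)CCc2c(ccc(C(=O)/C=C/c3ccc(OCc4cn(-c5ccc(Br)cc5)nn4)cc3)c2O)O1` gives 129000 nM, a high number on this read-out. Compound 2 `Cc1ccc(-n2cc(COc3ccc(/C=C/C(=O)c4ccc5c(c4O)CCC(C)(C)O5)cc3)nn2)cc1Br` is reported as "not active" (no number reported), so it stands without a single number and cannot be placed exactly on the scale.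

The next compound to be examined is compound 3 `CC1(C)CCc2c(ccc(C(=O)/C=C/c3ccc(OCc4cn(Cc5ccc([N+](=O)[O-])cc5)nn4)cc3)c2O)O1`. Its difference from compound 2 is 4-nitrobenzyl in place of 3-bromo-4-methylphenyl on an aromatic nitrogen, with 4-nitrobenzyl in place of 3-bromo-4-methylphenyl on an aromatic nitrogen of the five-membered aromatic ring.

For the measured compounds named here, no measured step for this kind of change is available, and compound 2 offers no number to count from, so the size of the step cannot be derived from the data. In this assay, a modest step towards stronger inhibition is expected, leaving compound 3 in the general region of compound 1 at 129000 nM. A second result without a number also remains possible.

For compound 3, the estimated half-maximal inhibitory concentration is 60000 nM, with an expected range of 12000 nM to 200000 nM.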

Compound 3, half-maximal inhibitory concentration: 69900 nM
Estimate against measurement, compound 3: 1.2-fold (0.07 log units) below; the measured number falls inside the stated range.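

In this assay, the aromatic nitrogen of the five-membered ring now has a second numbered result: 4-nitrobenzyl in place of 4-bromophenyl gives a 1.8-fold lower number from compound 1 to compound 3 (0.27 log units; within the scatter) on this read-out, so these two groups cannot be told apart here, and the position carries a benzyl group as well as a phenyl group without a change beyond the scatter. Compound 2 carries no number, so the step from it to compound 3 cannot be read, and its "not active" report can be set beside compound 3 only as a printed result, not as a measured difference. Nothing available explains why these results fall as they do.

The exchange alters both the link to the ring and the group on that ring at once, so the compounds shown leave open what each part contributes, a question that 4-bromobenzyl or 4-nitrophenyl on the same nitrogen would address. Also open, from the compounds shown here alone, is whether a different kind of group at this position, such as a longer chain ending in an amine or a carboxylic acid, would shift the number beyond the scatter.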